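The compounds below may be only part of what the source reports. "The series", "measured", "known", "first", "only" and "open" are said of these compounds alone.

In a physicochemical assay for solubility (on this read-out lower numbers stand for lower solubility and higher numbers for higher solubility), three compounds have been measured so far. Compound 1, `COc1cc2c(Nc3cnc(OCCCC4CCCC4)nc3)ncnc2cc1OCCCN1CCCCC1`, gives 130000 nM, and compound 2, `CNC(=O)c1cnc(Nc2ccc(OC)cc2C)nc1NC1CCCC1`, gives 10000 nM. Compound 3, `CNC(=O)c1sc(N2CC3CC2(CNC(=O)c2c[nH]c4ncc(C(F)(F)F)cc24)C3)nc1C(F)(F)F`, has no number, only a limit of < 1600 nM. This reading is the limit of < 1600 nM in this assay, at which 1 of the 3 values shown sits.

Compound 4, `CNC(=O)c1sc(N2CC3CC2(CNC(=O)c2c[nH]c4ncccc24)C3)nc1C(F)(F)F`, has the structure of compound 3 with one change: hydrogen in place of trifluoromethyl on an aromatic carbon. That carbon lies on a six-membered aromatic ring with 1 nitrogen, part of a fused or bridged system of two rings. For the measured compounds named here, no measured pair of compounds shows this change, so the expectation is a loose one, and the true size of the step cannot be pinned down from a limit.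

A moderate rise in this assay, beyond the usual scatter, is nevertheless expected, and the estimated step is an at least 3.7-fold higher number from compound 3 to compound 4 (0.57 log units; beyond the scatter). Going by the values given here, the only numbers available as a guide are those of compound 1 and compound 2, and compound 2, at 10000 nM, is the closer of the two to this expectation. Compound 4 is expected to read 6000 nM, with an estimated range from 1600 nM to 30000 nM.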

Compound 4, solubility: < 1600 nM
Compound 4: no number, only a limit; the forecaster's own chance of this, stated with the estimate: 25%; at least 3.7-fold (0.57 log units) between middle value and limit.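

In this assay compound 4 gives < 1600 nM, which is a limit and not a number. Compound 3 also has only a limit, so no step can be read from compound 3 to compound 4, and both rest at the same reading: the limit of < 1600 nM in this assay, at which 2 of the 4 values shown sit. The compounds shown leave open what hydrogen in place of trifluoromethyl on this aromatic carbon does to the read-out.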